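The source may hold more compounds than are shown below. What is called first, only, known or untested is meant among the compounds shown, and "the series" means these compounds.

Working notes on the series. Going by the values given here, in an ADME assay on L1210/0 cells (Mus musculus) for cytotoxicity, with a stated time of 48 h (a lower number here means a stronger inhibitor, a higher number a weaker inhibitor), compound 1 `C=Cc1cn([C@H]2C[C@H](O)[C@@H](CO)O2)c(=O)[nH]c1=O` gives 14200 nM, the only true number available so far. Compound 2 `O=c1ccn(C[C@@H]2C[C@H](CO)c3ccccc32)c(=O)[nH]1` reads > 200000 nM, which is a limit of the assay and not a number. Compound 3 `O=c1ccn(COCCO)c(=O)[nH]1` reads > 200000 nM, which is likewise a limit. Among the compounds with values here, the rest of the picture is therefore (the limit of > 200000 nM in this assay, at which 2 of the 3 values shown sit), and compound 1 is the only compound that can anchor a numerical comparison.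

The next compound is compound 4 `O=c1[nH]c(=O)n([C@H]2C[C@H](O)[C@@H](CO)O2)cc1C#CCCO`, which keeps the core of compound 1 and has 4-hydroxybut-1-yn-1-yl in place of vinyl on an aromatic carbon. Within the data shown here, no measured pair isolates a change at this carbon, so the expectation rests on the value of compound 1 and the structural change alone, and it stays loose. A move toward weaker inhibition in this assay is expected, with the estimated size given by a 3.5-fold higher number from compound 1 to compound 4 (0.55 log units; beyond the scatter). The assay may also report only a limit for this compound. For compound 4 the estimated value is 50000 nM, with an expected range of 12000 nM to 200000 nM.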

Compound 4, half-maximal inhibitory concentration: > 200000 nM
Compound 4 ended at the assay's limit (the forecaster's own chance of this, stated with the estimate: 35%); at least 4.0-fold (0.60 log units) between middle value and limit.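

Going by these compounds alone, compound 4 gives the first comparison at this aromatic carbon on the core of compound 1, and in this assay the change from vinyl to 4-hydroxybut-1-yn-1-yl reads as an at least 14-fold higher number from compound 1 to compound 4 (1.14 log units; beyond the scatter). For compound 4 the reading of > 200000 nM is a limit of the assay and not a number. The step therefore has a minimum size only, the position clearly does not tolerate this particular replacement in this assay, and compound 1 remains the only compound in the series with a true number: the limit of > 200000 nM in this assay, at which 3 of the 4 values shown sit.

The single step changes the double bond to a triple bond, lengthens the chain and adds a hydroxyl all at once, and the compounds shown cannot separate these three changes. On these data alone, whether a plain ethynyl group, a but-1-yn-1-yl chain without the hydroxyl, or a 2-bromovinyl group at the same carbon would stay near the value of compound 1 remains open, as does the true size of the step, which needs a compound that reads short of the limit.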